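Pyrazolyl enone cytotoxicity notes: halogen swap on the aryl ketone

This account rests on a few compounds, and the source may have more. Where it says the series, first, only, none or still open, it means among the compounds named here.

Measured so far:
Compound 1 `COc1ccc(-c2cc(/C=C/C(=O)c3ccc(N)cc3)[nH]n2)cc1` — 52%
Compound 2 `COc1cc(-c2cc(/C=C/C(=O)c3ccc(Cl)c(Cl)c3)[nH]n2)cc(OC)c1OC` — 107%

In a functional assay on OVCAR-4 cells (Homo sapiens) for cytotoxicity, read by sulforhodamine B assay, with a stated time of 48 h, tested at 1 uM (a lower number here means a stronger effect, a higher number a weaker effect of the compound at the concentration tested), compound 1 gives 52%, while compound 2 gives 107%, the higher of the two numbers and a gap beyond the scatter.

Compound 3 `COc1cc(-c2cc(/C=C/C(=O)c3ccc(F)c(F)c3)[nH]n2)cc(OC)c1OC` is not yet measured. It differs from compound 2 by 3,4-difluorophenyl in place of 3,4-dichlorophenyl on a carbonyl carbon. Going by the values given here, no step between measured compounds is available for this change; the two halogens counted are of the same number and kind of placement, so a step within the scatter is expected. Compound 3 is expected to show a number 7 percentage points lower from compound 2 to compound 3 (within the scatter), giving an estimated value of 100%, range 85% to 115%.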

Compound 3, a percentage reported as activity, at one concentration (the size of the read-out at that concentration, not a potency): 67%
For compound 3 the middle estimate is 33 percentage points above the measured one; the whole stated range lies above it.
By their numbers in this assay, from the lowest: compound 1; then compound 3; then compound 2.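

In this assay the position on the carbonyl carbon proves sensitive to the identity of the halogen: 3,4-difluorophenyl in place of 3,4-dichlorophenyl gives a number 40 percentage points lower from compound 2 to compound 3 (beyond the scatter). The two groups match in heavy atom count, ring, donors, acceptors and charge, so none of these counted features separates them, and the step follows the halogen alone. Nothing measured on these compounds accounts for the size of this step.

This single step gives no trend across the halogens. From the compounds shown here alone, how a methoxy group, a nitrile or a carboxylic acid on this phenyl ring would compare remains open.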